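The source may hold more compounds than are shown below. What is called first, only, known or untested is meant among the compounds shown, and "the series" means these compounds.

Compound 3 `C=CCn1c(=O)/c(=C\c2ccc(Cl)c(Cl)c2)[nH]c(=O)/c1=C\c1ccccc1OC` stands apart from its two measured relatives. Among the measured compounds shown here, in a functional assay on U-937 cells (Homo sapiens) for cytotoxicity, read by CCK-8 assay, with a stated time of 72 h (on this read-out higher numbers stand for weaker inhibition and lower numbers for stronger inhibition), compound 1 `C=CCn1c(=O)/c(=C\c2ccccc2Cl)[nH]c(=O)/c1=C\c1ccccc1OC` gives 700 nM, and compound 2 `C=CCn1c(=O)/c(=C\c2cccc(Cl)c2Cl)[nH]c(=O)/c1=C\c1ccccc1OC` gives 500 nM; the only step between compounds that differ in one place, a 1.4-fold lower number from compound 1 to compound 2 (0.15 log units; within the scatter), is a change of chloro in place of hydrogen on an aromatic carbon. Compound 3, by contrast, is reported in this assay only as "not active" (no number reported), so no number anchors it.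

Compound 4 `C=CCn1c(=O)/c(=C\c2cc(Br)ccc2F)[nH]c(=O)/c1=C\c1ccccc1OC` differs from compound 3 by 5-bromo-2-fluorophenyl in place of 3,4-dichlorophenyl on a double-bonded chain carbon bound to an aromatic carbon. For the measured compounds named here, no measured step bears directly on this exchange of one halogenated ring for another, and the one step that exists, from compound 1 to compound 2, is within the scatter and involves a different substitution. The direction from compound 3 to compound 4 therefore cannot be read from the data; it can only be framed by the numbers of compounds 1 and 2 on one side and the absence of activity for compound 3 on the other.

On that basis compound 4 is expected in this assay to give roughly 1500 nM, with a wide range from 400 nM to 10000 nM.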

Compound 4, half-maximal inhibitory concentration: 4700 nM
Compound 4: middle estimate off by 3.1-fold (0.50 log units), on the low side, and the stated range covers the measured number.
By their numbers in this assay, from the lowest: compounds 2 and 1 (each within the scatter of the next); then compound 4.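

On this double-bonded chain carbon, the identity of the halogenated ring now makes a difference beyond the scatter in this assay: 5-bromo-2-fluorophenyl in place of 2,3-dichlorophenyl gives a 9.4-fold higher number from compound 2 to compound 4 (0.97 log units; beyond the scatter), and in place of 2-chlorophenyl it gives a 6.7-fold higher number from compound 1 to compound 4 (0.83 log units; beyond the scatter). Among the compounds shown here, the only earlier step, which added a second chloro to the ring, stayed within the scatter, so these compounds are the first to show that a ring exchange here can move the number measurably, although compound 4 still has a number where compound 3 is reported only as not active. Nothing available accounts for this rise.

The compounds shown leave open whether the bromine, the fluorine or the two together go with the higher number, as no ring here carries either halogen alone. They also leave open how this position would respond to a ring bearing an amine or a carboxylic acid in place of halogen.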